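Replacing the Ethyl on the Amide Nitrogen with Pyridine

A few compounds are considered here, and "the series" means these few. Any claim that something is new, unique, unknown or untested is made for them only; others in the source may bear on it.

Compound 1 `CCN(Cc1cccs1)C(=O)COc1ccc(C)cc1` is an amide built from an aryloxyacetic acid and a tertiary amine that carries an ethyl group and a thiophene-bearing chain carbon. In an assay on HEK293 cells for agonist activity at transient receptor potential cation channel subfamily M member 8 (Homo sapiens), read by fluorescence and calcium flux, with a stated time of 15 min (a lower number here means that less compound is needed, a higher number that more compound is needed for the effect), compound 1 gives 8 nM. Two related compounds have been measured alongside it. Compound 2 `CCN(Cc1ccoc1)C(=O)COc1ccc(C)cc1` gives 136 nM, and compound 3 `CCc1ccc(OCC(=O)N(CC)Cc2cccs2)cc1` gives 67 nM. Compound 1 therefore stands with the lowest number of the three: the change a 17-fold higher number from compound 1 to compound 2 (1.23 log units; beyond the scatter), and the change an 8.4-fold higher number from compound 1 to compound 3 (0.92 log units; beyond the scatter). Both measured steps thus point the same way, upward, and both lie beyond the scatter.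

Compound 4 `Cc1ccc(OCC(=O)N(Cc2cccs2)c2ccccn2)cc1` differs from compound 1 in a single place: pyridin-2-yl in place of ethyl on an amide-type nitrogen. Within the data shown here, no measured step touches the amide nitrogen, so nothing here speaks directly to this change. What the two steps do show is that compound 1 sits at a low number from which changes elsewhere in the molecule have so far only moved it upward. On that basis a rise is expected for compound 4 as well, and a step of about a 5.0-fold higher number from compound 1 to compound 4 (0.70 log units; beyond the scatter) is estimated. For compound 4 in this assay the expected value is 40 nM, with a likely range from 8 nM to 250 nM.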

Compound 4, half-maximal effective concentration: 200 nM
For compound 4 the middle estimate is 5.0-fold (0.70 log units) below the measured one; low and high end bracket the measured number.
By their numbers in this assay, from the lowest: compound 1; then compound 3; then compounds 2 and 4 (each within the scatter of the next).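

In this assay, the amide nitrogen now has a measured step of its own, a 25-fold higher number from compound 1 to compound 4 (1.40 log units; beyond the scatter), so this position does respond to what it carries, at least for this one exchange of pyridin-2-yl for ethyl. The exchange changes several things at once: the entering group brings more heavy atoms, a six-membered aromatic ring, a ring nitrogen and one hydrogen-bond acceptor, while the ethyl it replaces has no ring and no acceptor. A single step cannot separate these features, and nothing available explains why the number rises.

A phenyl group on the amide nitrogen would keep the six-membered aromatic ring without the ring nitrogen, and a propyl chain there would extend the ethyl without adding a ring, so either could help show which feature goes with the rise. Going by these compounds, it also remains open whether pyridin-3-yl or pyridin-4-yl, with the ring nitrogen placed differently, would give a number closer to that of compound 1.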